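Replacing the 4-methoxyphenyl group of compound 3

The source may hold more compounds than are shown below. What is called first, only, known or untested is meant among the compounds shown, and "the series" means these compounds.

Three compounds that share one core and differ only in the group on a carbonyl carbon have been measured in an ADME assay on L6 cells (Rattus norvegicus) for cytotoxicity; a lower number here means a stronger inhibitor, a higher number a weaker inhibitor. There, compound 1 `CCNC(=O)c1noc(-c2cc(C(C)C)c(O)cc2O)c1NC(=O)C1CCC(OC)CC1` gives 15 nM, compound 2 `CCNC(=O)c1noc(-c2cc(C(C)C)c(O)cc2O)c1NC(=O)[C@@H]1CC[C@H](C(=O)OC)C1` gives 40 nM, and compound 3 `CCNC(=O)c1noc(-c2cc(C(C)C)c(O)cc2O)c1NC(=O)c1ccc(OC)cc1` gives 7 nM. Compound 3 thus has the lowest number of the three.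

Compound 4 `CCNC(=O)c1noc(-c2cc(C(C)C)c(O)cc2O)c1NC(=O)c1cc(CC)on1` has not yet been measured. It carries 5-ethyl-1,2-oxazol-3-yl in place of 4-methoxyphenyl on a carbonyl carbon.

All three measured steps bear on this change, since they occur at the same place. They are a 2.1-fold lower number from compound 1 to compound 3 (0.33 log units; beyond the scatter), a 5.7-fold lower number from compound 2 to compound 3 (0.76 log units; beyond the scatter) and a 2.7-fold higher number from compound 1 to compound 2 (0.43 log units; beyond the scatter). Each lies beyond the scatter, yet all are modest. Going by these compounds, none of them involves a five-membered aromatic ring with 2 hetero atoms, so the entering group remains untested in this set. With compound 3 at 7 nM, the low end of the measured range, a small move towards a higher number seems the likelier outcome in this assay. The expected change is a 1.7-fold higher number from compound 3 to compound 4 (0.23 log units; within the scatter), a step of modest size at most. For compound 4 the estimate is 12 nM, with an expected range from 4 nM to 35 nM.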

Compound 4, half-maximal inhibitory concentration: 20 nM
The estimate for compound 4 lay 1.7-fold (0.22 log units) below the measured number; the range from low to high includes it.
By their numbers in this assay, from the lowest: compound 3; then compounds 1, 4 and 2 (each within the scatter of the next, the first and the last beyond it).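

In this assay, the 5-ethyl-1,2-oxazol-3-yl group is the only five-membered aromatic ring with 2 hetero atoms at this place, on a carbonyl carbon whose other neighbour is an amide-type nitrogen, and exchanging the 4-methoxyphenyl group for it gives a step beyond the scatter (a 2.9-fold higher number from compound 3 to compound 4 (0.46 log units; beyond the scatter)). Compound 4 cannot be told apart from either compound with a non-aromatic ring at this place, as both steps lie within the scatter (a 2.0-fold lower number from compound 2 to compound 4 (0.30 log units; within the scatter); a 1.3-fold higher number from compound 1 to compound 4 (0.12 log units; within the scatter)), so having an aromatic ring here does not by itself match compound 3, which alone stands beyond the scatter of all the others. Nothing given here accounts for the difference between these two aromatic groups.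

The compounds shown leave open what the ethyl chain contributes, since a 1,2-oxazol-3-yl ring bearing no chain or a longer propyl chain would separate the chain from the ring itself. They also leave open what the methoxy group of compound 3 contributes, which an unsubstituted phenyl or a 4-aminophenyl group at the same place would address.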